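A few compounds are considered here, and "the series" means these few. Any claim that something is new, unique, unknown or untested is made for them only; others in the source may bear on it.

This account follows a single change made to compound 1 `CN(C[C@H]1Cc2c(cccc2N2CCN3CCC[C@H]3C2)CN1)[C@H]1CCCc2cccnc21`. In a functional assay on CCRF-CEM cells for antagonist activity at C-X-C chemokine receptor type 4 (Homo sapiens), read by calcium flux, with stated times of 25 min and 90 s (a higher number here means a weaker inhibitor, a lower number a stronger inhibitor), compound 1 gives 2.92 nM, the lowest of the two numbers measured. The nearest is compound 3 `CCCN(C[C@H]1Cc2c(cccc2N2CCNCC2)CN1)[C@H]1CCCc2cccnc21`, which in this assay gives 32.2 nM, a higher number by a gap that lies beyond the scatter of repeated runs. Compound 2 `CN(C[C@H]1Cc2c(cccc2N2CCN(c3cccc(C(F)(F)F)c3)CC2)CN1)[C@H]1CCCc2cccnc21` reaches only a limit of this assay, > 16700 nM, and no number. One of the three values shown is thus a limit: the limit of > 16700 nM in this assay, at which 1 of the 3 values shown sits.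

Compound 4 `CN(C[C@H]1Cc2c(cccc2N2C[C@H]3C[C@@H]2CN3)CN1)[C@H]1CCCc2cccnc21` differs from compound 1 in one place: a group of 7 heavy atoms (5 carbon, 2 nitrogen; 2 five-membered non-aromatic rings with 1 hetero atom each) in place of a group of 9 heavy atoms (7 carbon, 2 nitrogen; one five-membered non-aromatic ring with 1 hetero atom, one six-membered non-aromatic ring with 2 hetero atoms), on an aromatic carbon. Among the compounds with values here, no step between two measured compounds isolates this change, so its size has to be judged from what the three values show. Compound 3 sits at a higher number than compound 1, and compound 2 gives only a limit, so the group on this aromatic carbon clearly matters to the read-out. The entering group of compound 4 is smaller than the one it replaces and carries one hydrogen-bond donor where the leaving group had none. Compound 4 is expected to show a modest rise in number, a 2.7-fold higher number from compound 1 to compound 4 (0.44 log units; beyond the scatter), a step of a size close to the edge of the scatter rather than a collapse. The estimate for compound 4 in this assay is 8 nM, within a range from 2.5 nM to 25 nM.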

Compound 4, half-maximal inhibitory concentration: 20.7 nM
Compound 4: the middle estimate sits 2.6-fold (0.41 log units) below what was measured, and the stated range covers the measured number.
By their numbers in this assay, from the lowest: compound 1; then compounds 4 and 3 (each within the scatter of the next). At a limit, above all of these: compound 2.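

Within the data shown here, the step in this assay, a 7.1-fold higher number from compound 1 to compound 4 (0.85 log units; beyond the scatter), is the first that isolates the group on this aromatic carbon with the rest of the molecule held fixed. It shows that this position accepts a different ring arrangement without a collapse: the entering group, with 2 five-membered non-aromatic rings, 1 hydrogen-bond donor and 2 defined stereocentres, still gives a measured number, though it does not match the group it replaces. Nothing measured here bears on why the step has this size.

The compounds shown leave open which difference carries the step, as ring size, the hydrogen-bond donor and the stereocentres all change together in this one replacement. They also leave open how a morpholine ring, a dimethylamino group or the mirror-image form of the entering group would read on this aromatic carbon of the core of compound 1.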